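Swapping the Aryl Group on a Weak Compound

A few compounds are considered here, and "the series" means these few. Any claim that something is new, unique, unknown or untested is made for them only; others in the source may bear on it.

compound 1 `COc1cc(C(=O)N/N=C/c2ccc(F)c(F)c2)cc(OC)c1OC` — 51.9%
compound 2 `COc1cc(C2=NN(C(C)=O)C(c3cc(Cl)cc(Cl)c3)O2)cc(OC)c1OC` — 6.6%
compound 3 `COc1cc(C(=O)N/N=C/c2ccc(C(F)(F)F)cc2)cc(OC)c1OC` — 56.3%

Of the compounds shown here, three have been measured in a functional assay on BGC-823 cells (Homo sapiens) for antiproliferative activity, read by MTT assay, tested at 5 uM; a lower number here means a weaker effect, a higher number a stronger effect of the compound at the concentration tested. Compound 1 gives 51.9% and compound 3 gives 56.3%, both with the same open chain core, while compound 2, built on a different core, gives 6.6%. Compound 2 stands lowest of the three numbers: its nearest neighbour is compound 1, a gap beyond the scatter, and compound 3 lies further away, also beyond the scatter. Within the data shown here, no two measured compounds differ in only one place, so no single step has been seen.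

Compound 4 `COc1cc(C2=NN(C(C)=O)C(c3ccccc3F)O2)cc(OC)c1OC` keeps the core of compound 2 and differs from it in one place: 2-fluorophenyl in place of 3,5-dichlorophenyl on a saturated ring carbon. Among the measured compounds shown here, with no measured step covering this kind of change, the expectation rests on compound 2 alone, and compound 4 is expected to stay low because compound 2 gives 6.6%. The expected step of a number 5.4 percentage points higher from compound 2 to compound 4 (within the scatter) is no larger than the scatter. Compound 4 is estimated at 12%, with a range from 0% to 35%.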

Compound 4, a percentage reported as inhibition, at one concentration (the size of the read-out at that concentration, not a potency): 32.8%
Estimate against measurement, compound 4: 20.8 percentage points below, and the stated range covers the measured number.
By their numbers in this assay, from the lowest: compound 2; then compound 4; then compounds 1 and 3 (each within the scatter of the next).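

In this assay, the aryl group on the saturated ring carbon proves to be a position that matters: 2-fluorophenyl in place of 3,5-dichlorophenyl gives a number 26.2 percentage points higher from compound 2 to compound 4 (beyond the scatter). Compound 2 and compound 4 share the same core. Among these compounds, the read-out moves when only this group changes. The swap changes the halogen and its place on the phenyl ring at once, and nothing at hand explains the rise.

The compounds shown leave open whether gaining the fluorine or losing the chlorines accounts for the step, and an unsubstituted phenyl on the same carbon would help separate the two. From the compounds shown here alone, how a phenyl ring bearing a methoxy group or an amine would behave at this position also remains open.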